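This account rests on a few compounds, and the source may have more. Where it says the series, first, only, none or still open, it means among the compounds named here.

Working notes on the series. Going by the values given here, in an assay on isolated protein for inhibition of ribosomal protein S6 kinase alpha-2 (Homo sapiens), with a stated time of 150 min (on this read-out higher numbers stand for weaker inhibition and lower numbers for stronger inhibition), two compounds have numbers so far. Compound 1 `COc1cccc(F)c1-c1cccc2nc(Nc3ccccc3)oc12` gives 1000 nM in this assay. Compound 2 `COc1ccccc1-c1cccc2nc(Nc3cc(OC)c(OC)c(OC)c3)oc12` gives 20 nM in this assay, the lowest of the two numbers shown; its nearest neighbour is compound 1, whose number is higher by a gap that lies beyond the scatter. Among the compounds with values here, the two compounds differ in more than one place, so no single step between them is counted, and their two numbers are all that can be said of the pair.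

Compound 3 `COc1cc(Nc2nc3cccc(-c4cccc5cn[nH]c45)c3o2)cc(OC)c1OC` has not been measured in this assay. It differs from compound 2 in one place: 1H-indazol-7-yl in place of 2-methoxyphenyl on an aromatic carbon, the entering group sitting on an aromatic carbon of a six-membered aromatic ring of carbon only, part of a fused system of two rings, ortho to a fused ring and meta to a fused ring. Within the data shown here, no comparable step has a measured value, so there is no counted precedent for the size or direction of this change. The expectation is that the step from compound 2 to compound 3 in this assay stays within the scatter, a 1.3-fold lower number from compound 2 to compound 3 (0.12 log units; within the scatter). For compound 3 the estimated value in this assay is 15 nM, with a range from 4 nM to 60 nM.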

Compound 3, half-maximal inhibitory concentration: 50 nM
Compound 3: middle estimate off by 3.3-fold (0.52 log units), on the low side, and the stated range covers the measured number.
By their numbers in this assay, from the lowest: compound 2; then compound 3; then compound 1.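

In this assay, going by these compounds alone, the swap of 2-methoxyphenyl for 1H-indazol-7-yl gives a 2.5-fold higher number from compound 2 to compound 3 (0.40 log units; beyond the scatter) as the first counted step at this place, an aromatic carbon of a six-membered aromatic ring of carbon only. The step is modest but real, so this place does not treat the two groups alike, even though both are aromatic and no net charge enters. Within the data shown here, the entering group adds a five-membered aromatic ring with 2 hetero atoms and a hydrogen-bond donor, and the single step cannot separate these two changes. Nothing measured on these compounds accounts for the size or direction of the step.

Open, going by these compounds, is whether a pyridin-3-yl or an unsubstituted phenyl at this place would stay nearer compound 2 or compound 3. Also open, on these data alone, is whether a 1H-indazol-5-yl would give a step of similar size.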